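Sulfonyl substituent change from compound 3 to compound 4

A few compounds are considered here, and "the series" means these few. Any claim that something is new, unique, unknown or untested is made for them only; others in the source may bear on it.

The series shares one amide-linked core, and readings are sparse. In an ADME assay on Vero cells (Chlorocebus sabaeus) for cytotoxicity, read by MTT assay (on this read-out higher numbers stand for lower toxicity in this test and lower numbers for higher toxicity in this test), compound 1 `COC(=O)c1ccccc1-n1nc(C(F)(F)F)cc1C(=O)Nc1ccc(S(=O)(=O)N2CCCC2)cc1` reads "not determined" (no result reported). Compound 2 `O=C(O)c1ccccc1-n1nc(C(F)(F)F)cc1C(=O)Nc1ccc(S(=O)(=O)N2CCCC2)cc1` reads "not determined" (no result reported). Compound 3 `Cn1nc(C(F)(F)F)cc1C(=O)Nc1ccc(S(=O)(=O)N2CCC[C@H]2C(=O)O)cc1` gives > 300000 nM, which is a limit of the assay and not a number. Compound 3 is therefore the only reference point in the series, and it offers a limit alone.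

Compound 4 `Cn1nc(C(F)(F)F)cc1C(=O)Nc1ccc(S(=O)(=O)N2CCC(N)CC2)cc1` carries 4-aminopiperidin-1-yl in place of 2-carboxypyrrolidin-1-yl on a sulfonyl sulfur. Within the data shown here, no pair of measured compounds provides a step to calibrate this change in this assay, so the expectation is a loose one. A modest move toward lower numbers, meaning higher toxicity in this test, is expected, and the estimated size is an at least 2.5-fold lower number from compound 3 to compound 4 (0.39 log units; beyond the scatter). A result reported only as a limit also remains possible for this change. The estimate for compound 4 is 120000 nM, with an expected range of 30000 nM to 300000 nM.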

Compound 4, half-maximal cytotoxic concentration: > 300000 nM
Compound 4: only a limit was reported; the forecaster's own chance of this, stated with the estimate: 40%; middle value at least 2.5-fold (0.39 log units) away from the limit.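

In this assay, no step can be read between compound 3 and compound 4 because both readings are limits and not numbers: the limit of > 300000 nM in this assay, at which 2 of the 4 values shown sit.

The compounds shown leave open whether 4-aminopiperidin-1-yl in place of 2-carboxypyrrolidin-1-yl on the sulfonyl sulfur changes this read-out at all.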